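The source may report more compounds than this note shows. Statements on the series, on what has been measured and on what is new or still open speak of the compounds shown alone.

Measured compounds:
Compound 1, `Cc1cc(C)c(Oc2cc(Nc3ccc(C#N)cc3)ncc2C(=O)NCc2cn(CC(=O)N3CCOCC3)nn2)c(C)c1`: 181000 nM
Compound 2, `CCOC(=O)CCn1cc(CNC(=O)c2cnc(Nc3ccc(C#N)cc3)cc2Oc2c(C)cc(C)cc2C)nn1`: 21500 nM
Compound 3, `Cc1cc(C)c(Oc2cc(Nc3ccc(C#N)cc3)ncc2C(=O)NCc2cn(CCC#N)nn2)c(C)c1`: 40200 nM

These three share one core and differ only in the group on a saturated chain carbon bound to an aromatic nitrogen. In an ADME assay on MT4 cells (Homo sapiens) for cytotoxicity, read by MTT assay, with a stated time of 5 days (on this read-out lower numbers stand for higher toxicity in this test and higher numbers for lower toxicity in this test), compound 3 stands second highest of the three numbers; compound 2 lies nearest to it, within the scatter, while compound 1 is furthest, as a 4.5-fold lower number from compound 1 to compound 3 (0.65 log units; beyond the scatter) shows, and a 1.9-fold higher number from compound 2 to compound 3 (0.27 log units; within the scatter) is within the scatter.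

Compound 4, `Cc1cc(C)c(Oc2cc(Nc3ccc(C#N)cc3)ncc2C(=O)NCc2cn(Cc3ccc([N+](=O)[O-])cc3)nn2)c(C)c1`, continues the series at the same place: 4-nitrophenyl in place of cyanomethyl on a saturated chain carbon bound to an aromatic nitrogen. Among the measured compounds shown here, the steps that bear on it are a 4.5-fold lower number from compound 1 to compound 3 (0.65 log units; beyond the scatter) and an 8.4-fold lower number from compound 1 to compound 2 (0.93 log units; beyond the scatter), both modest, and a 1.9-fold higher number from compound 2 to compound 3 (0.27 log units; within the scatter), within the scatter. Changes at this position have so far shifted the number modestly, with the smaller groups giving the lower numbers. Nothing measured shows an aromatic group here. Compound 4 is therefore expected to give a modest step, a 1.6-fold lower number from compound 3 to compound 4 (0.21 log units; within the scatter), toward a lower number. The estimate for compound 4 is 25000 nM, with a range from 8000 nM to 80000 nM.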

Compound 4, half-maximal cytotoxic concentration: >= 139000 nM
Compound 4 was reported as a limit; the forecaster's own chance of this, stated with the estimate: 15%; middle value at least 5.5-fold (0.74 log units) away from the limit.
By their numbers in this assay, from the lowest: compounds 2 and 3 (each within the scatter of the next); then compound 1.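

Compound 4 is reported only as a limit, not as a number: the limit of >= 139000 nM in this assay, at which 1 of the 4 values shown sits.

Among the compounds shown here, with 4-nitrophenyl, the first aromatic group at this place, the series shows an at least 3.4-fold higher number from compound 3 to compound 4 (0.53 log units; beyond the scatter) and an at least 6.4-fold higher number from compound 2 to compound 4 (0.81 log units; beyond the scatter), so compound 1 is no longer the only compound whose number stands beyond the scatter of those of compound 2 and compound 3 in this assay. The earlier link between smaller groups and lower numbers therefore does not extend to size alone, as the larger ester of compound 2 and the nitrile of compound 3 already lay within the scatter of each other, and the step between compound 1 and compound 4 cannot be read.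

The compounds shown do not separate the benzene ring from its nitro group. On these data alone, how a plain benzyl, or an amine in place of the nitro group, would read in this assay stays open.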